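Compound 3: fluoro in place of hydrogen

The source may report more compounds than this note shows. Statements on the series, on what has been measured and on what is new or still open speak of the compounds shown alone.

Compound 1 `CO/N=C1/C(=O)N(Cc2cn(CC(=O)N3CCN(c4cc5c(cc4F)c(=O)c(C(=O)O)cn5C4CC4)CC3)nn2)c2c(F)cccc21` reads 32 ug/mL as measured
Compound 2 `CCO/N=C1/C(=O)N(Cc2cn(CC(=O)N3CCN(c4cc5c(cc4F)c(=O)c(C(=O)O)cn5C4CC4)CC3)nn2)c2ccccc21` reads 64 ug/mL as measured

In an ADME assay on Vero cells (Chlorocebus sabaeus) for cytotoxicity (on this read-out higher numbers stand for lower toxicity in this test and lower numbers for higher toxicity in this test), compound 2 at 64 ug/mL stands within the usual scatter of compound 1, so these two values cannot be separated. Compound 3 `CCO/N=C1/C(=O)N(Cc2cn(CC(=O)N3CCN(c4cc5c(cc4F)c(=O)c(C(=O)O)cn5C4CC4)CC3)nn2)c2c(F)cccc21` carries fluoro in place of hydrogen on an aromatic carbon of compound 2. Within the data shown here, no measured pair isolates this change, so no step beyond the scatter is expected in this assay in either direction. The expected step of a 1.4-fold lower number from compound 2 to compound 3 (0.15 log units; within the scatter) is therefore small. Compound 3 is estimated at 45 ug/mL in a range from 16 ug/mL to 128 ug/mL when measured.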

Compound 3, half-maximal cytotoxic concentration: 16 ug/mL
Compound 3: middle estimate off by 2.8-fold (0.45 log units), on the high side; the range from low to high includes it.
By their numbers in this assay, from the lowest: compounds 3, 1 and 2 (each within the scatter of the next, the first and the last beyond it).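

In this assay, among these compounds, fluoro in place of hydrogen on an aromatic carbon gives a 4.0-fold lower number from compound 2 to compound 3 (0.60 log units; beyond the scatter), the only step here beyond the scatter, so this aromatic position can shift the read-out. The methyl in place of hydrogen on the saturated chain carbon gives a 2.0-fold lower number from compound 1 to compound 3 (0.30 log units; within the scatter), which leaves that change unresolved with fluoro present. Nothing available explains the fluoro step. From the compounds shown here alone, whether chloro or an amine on the same aromatic carbon would read like fluoro remains open, as does whether a longer chain on the oxygen would alter the read-out.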